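Adding a Trifluoromethyl Group to the Phenoxy Ring

A few compounds are considered here, and "the series" means these few. Any claim that something is new, unique, unknown or untested is made for them only; others in the source may bear on it.

Of the compounds shown here, two have so far been tested in a functional assay on MIA PaCa-2 cells (Homo sapiens) for antiproliferative activity, read by MTT assay, with a stated time of 72 h; a lower number here means that less compound is needed, a higher number that more compound is needed for the effect. Compound 1 `Cc1nn(Cc2cccc(C(=O)Nc3ccccc3)c2)c(C)c1NC(=O)c1ccc(COc2ccccc2)cc1` gives 6400 nM. Compound 2 `CNC(=O)c1cccc(Cn2nc(C)c(NC(=O)c3ccc(COc4ccccc4C)cc3)c2C)c1` gives 2100 nM, the lower of the two numbers, and the gap to compound 1 lies beyond the usual scatter. Compound 3 `CNC(=O)c1cccc(Cn2nc(C)c(NC(=O)c3ccc(COc4ccc(C(F)(F)F)cc4C)cc3)c2C)c1` has not yet been measured; it differs from compound 2 in one place: trifluoromethyl in place of hydrogen on an aromatic carbon. Among the compounds with values here, no measured pair shows this same change, so its effect is unknown. A small step, within the usual scatter, is expected, a 1.4-fold lower number from compound 2 to compound 3 (0.15 log units; within the scatter). For compound 3 the estimated value is 1500 nM, with a range from 500 nM to 5000 nM.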

Compound 3, half-maximal effective concentration: 620 nM
Estimate against measurement, compound 3: 2.4-fold (0.38 log units) above; the range from low to high includes it.
By their numbers in this assay, from the lowest: compound 3; then compound 2; then compound 1.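

The carbon para to the large group on the 2-methylphenoxy ring is a place where a change moves the number: adding trifluoromethyl there brings a 3.4-fold lower number from compound 2 to compound 3 (0.53 log units; beyond the scatter) in this assay. Within the data shown here, this is the first single-place step, and it is modest but clear of the scatter. Nothing measured here accounts for it.

As far as these compounds go, whether the gain is specific to trifluoromethyl remains open, since a chlorine atom, a nitrile or a methoxy group on the same carbon could give a similar number. A single step also cannot show whether the change would act the same way on other members of the series.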